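Thiophene sulfonyl in place of the indole carbonyl

A few compounds are considered here, and "the series" means these few. Any claim that something is new, unique, unknown or untested is made for them only; others in the source may bear on it.

Compound 3 `CCCCCCCCCCCCCCCCCCNC(=O)[C@@H](NC(=O)c1cc2ccccc2n1C)[C@@H](C)O` sits at a limit of a functional assay on HepG2 cells (Homo sapiens) for cytotoxicity, read by MTT assay, with a stated time of 48 h; on this read-out higher numbers stand for weaker inhibition and lower numbers for stronger inhibition: compound 3 gives > 200000 nM, which is a limit and not a number. Compound 2 `CCCCCCCCCCCCCCCCCCNC(=O)[C@@H](NC(=O)c1cc2ccccc2o1)[C@@H](C)O` likewise sits at a limit: in this assay compound 2 gives > 200000 nM. Compound 1 `CCCCCCCCCCCCCCCCCCNC(=O)[C@@H](NC(=O)c1ccco1)[C@@H](C)O` is the only one of the three with a number: in this assay compound 1 gives 42300 nM. Starting from its furan-2-yl carbonyl, the measured steps were an at least 4.7-fold higher number from compound 1 to compound 2 (0.67 log units; beyond the scatter) and an at least 4.7-fold higher number from compound 1 to compound 3 (0.67 log units; beyond the scatter), while between the two limits a step that the two limits leave unreadable from compound 2 to compound 3; the open-ended size of the first two steps comes from the limit of > 200000 nM in this assay, at which 2 of the 3 values shown sit.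

Compound 4 `CCCCCCCCCCCCCCCCCCNC(=O)[C@@H](NS(=O)(=O)c1cccs1)[C@@H](C)O` arises through ((thiophen-2-yl)sulfonyl in place of (1-methyl-1H-indol-2-yl)carbonyl on an amine nitrogen). The change removes the bicyclic group that, in compounds 2 and 3, went with the weaker figures, and restores a single five-membered aromatic ring as in compound 1, though now linked by a sulfonyl rather than a carbonyl. Among the compounds with values here, no measured step covers a sulfonyl on this nitrogen. Compound 4 is therefore expected to move back toward compound 1, so that an at least 2.5-fold lower number from compound 3 to compound 4 (0.39 log units; beyond the scatter) is the expected step. Compound 4 is estimated at 80000 nM, with a likely range from 20000 nM to 300000 nM.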

Compound 4, half-maximal inhibitory concentration: > 200000 nM
Compound 4 gave a limit, no number; the forecaster's own chance of this, stated with the estimate: 40%; middle value at least 2.5-fold (0.39 log units) away from the limit.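

In this assay compound 4 gives > 200000 nM, which is a limit and not a number. Within the data shown here, a single five-membered aromatic ring on this amine nitrogen is therefore not enough to give a number, since the (thiophen-2-yl)sulfonyl group shows an at least 4.7-fold higher number from compound 1 to compound 4 (0.67 log units; beyond the scatter), and compound 1 remains the only compound of the four with a number. The steps to compound 4 from compound 3 and from compound 2 cannot be read because all three compounds sit at the same limit: the limit of > 200000 nM in this assay, at which 3 of the 4 values shown sit.

The step from compound 1 changes the ring and the link together, so the compounds shown do not separate thiophene from sulfonyl. From the compounds shown here alone, whether a (thiophen-2-yl)carbonyl or a (furan-2-yl)sulfonyl group on this nitrogen would give a number remains open.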